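Swapping the Amide Substituent: Cytotoxicity Expectation for Compound 3

The source may hold more compounds than are shown below. What is called first, only, known or untested is meant among the compounds shown, and "the series" means these compounds.

For the measured compounds named here, compound 2 `O=C(NCCCc1ccncc1)C1CCN(C(=O)c2cc3ccccc3n2Cc2ccc(Cl)cc2)CC1` gives 71500 nM in an ADME assay on BE(2)-C cells (Homo sapiens) for cytotoxicity, read by MTT assay, with a stated time of 20 h (on this read-out higher numbers stand for lower toxicity in this test and lower numbers for higher toxicity in this test), the lowest of the two numbers so far, although compound 1 `CN1CCN(C(=O)C2CCN(C(=O)c3cc4ccccc4n3Cc3ccc(Cl)cc3)CC2)CC1` at 75600 nM sits within the scatter of it. Going by the values given here, the only measured step, a 1.1-fold lower number from compound 1 to compound 2 (0.02 log units; within the scatter), also changed the group on a carbonyl carbon and left the number essentially where it was. Compound 3 `O=C(c1cc2ccccc2n1Cc1ccc(Cl)cc1)N1CCC(C(=O)N2CCCC2)CC1` carries pyrrolidin-1-yl in place of (3-(pyridin-4-yl)propyl)amino on a carbonyl carbon. Among the compounds with values here, with only that within-scatter step to draw on, no change beyond the scatter is expected here, a 1.0-fold lower number from compound 2 to compound 3 (0.01 log units; within the scatter). Compound 3 is therefore estimated at 70000 nM, with a range from 35000 nM to 140000 nM.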

Compound 3, half-maximal cytotoxic concentration: 65600 nM
Compound 3: middle estimate off by 1.1-fold (0.03 log units), on the high side; the measured number falls inside the stated range.
By their numbers in this assay, from the lowest: compounds 3, 2 and 1 (each within the scatter of the next).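

In this assay, the group on the carbonyl carbon can shrink from 10 heavy atoms to 5 and lose its aromatic ring and hydrogen-bond donor, and the result is still only a 1.1-fold lower number from compound 2 to compound 3 (0.04 log units; within the scatter) for this swap. Replacing 4-methylpiperazin-1-yl with pyrrolidin-1-yl gives a 1.2-fold lower number from compound 1 to compound 3 (0.06 log units; within the scatter), so all three groups lie within the scatter of one another. Nothing measured here bears on why. As far as these compounds go, whether a carboxylic acid, a primary amine or a longer chain on this carbonyl carbon would move the number beyond the scatter remains open.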